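This account rests on a few compounds, and the source may have more. Where it says the series, first, only, none or still open, it means among the compounds named here.

In a functional assay on CFPAC-1 cells (Homo sapiens) for inhibition, read by MTT assay, with a stated time of 72 h (on this read-out lower numbers stand for stronger inhibition and higher numbers for weaker inhibition), three measured compounds share the core of compound 1 `O=c1cc(Cn2cc(-c3cc(F)cc(F)c3)nn2)c2ccc(O)cc2o1`. Compound 1 reaches only the limit of the assay, > 100000 nM. Compound 2 `CCCCCCc1ccc(-c2cn(Cc3cc(=O)oc4cc(O)ccc34)nn2)cc1` likewise gives only a limit, > 100000 nM. Going by the values given here, compound 3 `O=c1cc(Cn2cc(CNS(=O)(=O)c3ccc(Cl)cc3)nn2)c2ccc(O)cc2o1` is the one compound that yields a number in this assay, 81900 nM. The two other values sit where the limit of > 100000 nM in this assay, at which 2 of the 3 values shown sit, records them, so compound 3 stands alone as the single measured point. Compound 4 `O=c1cc(Cn2cc(CNS(=O)(=O)c3ccc(F)cc3Cl)nn2)c2ccc(O)cc2o1` differs from compound 3 in one place: 2-chloro-4-fluorophenyl in place of 4-chlorophenyl on a sulfonyl sulfur. Among the compounds with values here, no step between two measured compounds is available to size such a change, so the expectation rests on the value of compound 3 81900 nM alone. The step of a 1.0-fold lower number from compound 3 to compound 4 (0.01 log units; within the scatter) is expected to stay within the usual scatter, with no settled direction. Compound 4 is therefore expected to give about 80000 nM in this assay, between 30000 nM and 200000 nM, with a fair chance that only a limit is reported.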

Compound 4, half-maximal inhibitory concentration: > 100000 nM
Compound 4: a limit, no number (the forecaster's own chance of this, stated with the estimate: 45%); middle value at least 1.2-fold (0.09 log units) from the limit.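

In this assay, 2-chloro-4-fluorophenyl in place of 4-chlorophenyl on a sulfonyl sulfur gives an at least 1.2-fold higher number from compound 3 to compound 4 (0.08 log units; that floor lies within the scatter). On these data alone, this step is only a floor, so the true size of the change remains unknown, and what is printed does not set it apart from the scatter. Compound 4 gives only a limit, so the sulfonyl position still has no second number to set beside compound 3: the limit of > 100000 nM in this assay, at which 3 of the 4 values shown sit.

The compounds shown leave open whether another group on the sulfonyl sulfur, such as a methyl or a plain phenyl, would give a clearly lower number in this assay. They also leave open whether an amide in place of the sulfonamide would keep any measurable inhibition at all.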